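The source may report more compounds than this note shows. Statements on the series, on what has been measured and on what is new or still open speak of the compounds shown alone.

Measured so far:
compound 1 `COc1ccc(CN2CCc3nc(-c4ccccn4)nc(N4CCN(CCN(C)C)CC4)c3C2)cc1` — "not active" (no number reported)
compound 2 `CN(C)CCN1CCN(c2nc(-c3ccccn3)nc3c2CN(CC2CCCCC2)CC3)CC1` — 41%

For the measured compounds named here, in an assay on FRT cells with Cystic fibrosis transmembrane conductance regulator variant F508del (Homo sapiens) as the target, read by fluorescence, with a stated time of 25 min (on this read-out higher numbers stand for larger maximal responses and lower numbers for smaller maximal responses), compound 2 gives 41%, the only number the series holds. Compound 1 gives "not active" (no number reported) in this assay, with no number attached, so the two cannot be set against each other beyond that. Going by the values given here, no step between two measured compounds that differ in one place is available.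

Compound 3 `CN(C)CCN1CCN(c2nc(-c3ccccn3)nc3c2CN(S(=O)(=O)c2ccccc2)CC3)CC1` follows from compound 2 through one change, (phenylsulfonyl in place of cyclohexylmethyl on an amine nitrogen in a ring). With a single number in hand, the size of this step is open. The expectation is a moderate fall rather than none, since compound 1, which also carries a different group on the same ring nitrogen, gives "not active" (no number reported). The step from compound 2 to compound 3 is estimated at a number 16 percentage points lower from compound 2 to compound 3 (beyond the scatter). Compound 3 is expected to reach 25% in this assay, within 0% to 50%.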

Compound 3, largest response reached (Emax), in percent of the reference or control that the assay uses in the Cystic fibrosis transmembrane conductance regulator assay: "not active" (no number reported)
Compound 3 has no reported number here, so the estimate cannot be set against anything.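

No new step can be read between compound 2 and compound 3 in the Cystic fibrosis transmembrane conductance regulator assay, where compound 3 gives "not active" (no number reported). In a physicochemical assay for solubility, read by HPLC, with a stated time of 24 h, at pH 7.4, tested at 250 uM (a lower number here means a less soluble compound, a higher number a more soluble compound), compound 2 gives 191000 nM and compound 3 gives 195000 nM, which is a 1.0-fold higher number from compound 2 to compound 3 (0.01 log units; within the scatter). The compounds shown leave open what separates compound 2 from compound 1 and compound 3 in the Cystic fibrosis transmembrane conductance regulator assay, and no available data bear on this.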